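The source may report more compounds than this note shows. Statements on the series, on what has been measured and on what is new or still open speak of the compounds shown alone.

Compound 1 `COc1cc(Nc2nc(C(=N)Nc3ccc(N4CCN(C)CC4)cc3)cc3c(-c4ccccc4)n[nH]c23)cc(OC)c1OC` and compound 2 `COc1ccc(Cn2nc(-c3ccccc3)c3cc(C(=N)Nc4ccc(N5CCN(C)CC5)cc4)nc(Nc4cc(OC)c(OC)c(OC)c4)c32)cc1` share a core. In a functional assay on MDA-MB-231 cells (Homo sapiens) for cytotoxicity, read by MTT assay, with a stated time of 72 h (on this read-out lower numbers stand for stronger inhibition and higher numbers for weaker inhibition), compound 2 gives 890 nM, and compound 1 gives 4600 nM. The step of a 5.2-fold higher number from compound 2 to compound 1 (0.71 log units; beyond the scatter) belongs to hydrogen in place of 4-methoxybenzyl on an aromatic nitrogen. Compound 3 `COc1ccc(Cn2nc(-c3ccccc3)c3cc(C(=N)Nc4cccc(C(F)(F)F)c4)nc(Nc4cc(OC)c(OC)c(OC)c4)c32)cc1` carries a different amidine partner; the difference between the two cores is not broken down here. In this assay compound 3 gives > 50000 nM, a limit of the assay rather than a number, the limit noted as the limit of > 50000 nM in this assay, at which 1 of the 3 values shown sits. Compound 4 `COc1cc(Nc2nc(C(=N)Nc3cccc(C(F)(F)F)c3)cc3c(-c4ccccc4)n[nH]c23)cc(OC)c1OC` is not yet measured and follows from compound 3 by hydrogen in place of 4-methoxybenzyl on an aromatic nitrogen, the same change as from compound 2 to compound 1. Because compound 3 stands at > 50000 nM and the earlier step of a 5.2-fold higher number from compound 2 to compound 1 (0.71 log units; beyond the scatter) raised the number, compound 4 is expected to remain at the limit, an expected step that the limit leaves unreadable from compound 3 to compound 4. The estimate for compound 4 in this assay is 150000 nM, with a likely range from 50000 nM to 500000 nM.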

Compound 4, half-maximal inhibitory concentration: 7600 nM
Compound 4: the middle estimate sits 20-fold (1.30 log units) above what was measured; the measured number lies below the stated range.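

Replacing 4-methoxybenzyl with hydrogen on the aromatic nitrogen gives an at least 6.5-fold lower number from compound 3 to compound 4 (0.81 log units; beyond the scatter) in this assay. Set beside the earlier step, the same change does not carry over from one core to the other, and its direction is opposite: the same change on two cores in this assay, a 5.2-fold higher number (0.71 log units; beyond the scatter) from compound 2 to compound 1 and an at least 6.5-fold lower number (0.81 log units; beyond the scatter) from compound 3 to compound 4, at least 34-fold (1.53 log units) apart, beyond the scatter of two such steps. Why the two cores part is not shown, two pairs give no rule for other amidine partners, and compound 3 stands at a limit of the assay, leaving the size of its step only a bound: the limit of > 50000 nM in this assay, at which 1 of the 4 values shown sits.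

Still open, on these data alone, is how a plain benzyl or a methyl on that aromatic nitrogen would read. Also open, as far as these compounds go, is whether an amidine partner bearing a carboxylic acid would follow compound 1 or compound 4.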